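Pyridin-2-yl in place of 4-cyanophenyl

The source may hold more compounds than are shown below. What is called first, only, known or untested is meant among the compounds shown, and "the series" means these compounds.

Measured so far in a physicochemical assay for solubility, in phosphate buffer, at pH 7.4; a lower number here means a less soluble compound, a higher number a more soluble compound 
Compound 1 `OC1CN(c2nccnc2OC2CN(c3ccc4ccccc4n3)C2)C1` gives 41000 nM 
Compound 2 `N#Cc1ccc(-c2nccnc2OC2CN(c3ccc4ccccc4n3)C2)cc1` gives < 1000 nM as a limit of the assay

Compound 2 has no number, only a limit (< 1000 nM). Among the compounds with values here, the one measured step in this assay is large: an at least 41-fold lower number from compound 1 to compound 2 (1.61 log units; beyond the scatter). That step took away the 3-hydroxyazetidin-1-yl group and brought in the 4-cyanophenyl group, and the size shown for it rests on that limit (the limit of < 1000 nM in this assay, at which 1 of the 2 values shown sits).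

Compound 3 `c1ccc(-c2nccnc2OC2CN(c3ccc4ccccc4n3)C2)nc1` differs from compound 2 in one place: pyridin-2-yl in place of 4-cyanophenyl on an aromatic carbon. Pyridin-2-yl takes the place of 4-cyanophenyl on the same aromatic carbon, so one six-membered aromatic ring replaces another and the 3-hydroxyazetidin-1-yl group stays absent. Within the data shown here, the step of an at least 41-fold lower number from compound 1 to compound 2 (1.61 log units; beyond the scatter) therefore bears on this change only indirectly, and no measured step swaps one such ring for another. A repeat of a change that large is not expected, and compound 3 should stay close to the limit of compound 2. The expected step is small, at most slightly upward: an at least 1.5-fold higher number from compound 2 to compound 3 (0.17 log units; that floor lies within the scatter). Compound 3 is estimated at 1500 nM (expected range 400 nM to 6000 nM).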

Compound 3, solubility: 349000 nM
Estimate against measurement, compound 3: 230-fold (2.37 log units) below; measured number above the stated range.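

In this assay, the outcome at this aromatic carbon depends on which aromatic ring sits there, not simply on whether a ring replaces the 3-hydroxyazetidin-1-yl group: exchanging 4-cyanophenyl for pyridin-2-yl gives an at least 340-fold higher number from compound 2 to compound 3 (2.54 log units; beyond the scatter). Pyridin-2-yl also surpasses the 3-hydroxyazetidin-1-yl group, with an 8.5-fold higher number from compound 1 to compound 3 (0.93 log units; beyond the scatter), so the earlier fall belongs to 4-cyanophenyl in particular, and neither the loss of the 3-hydroxyazetidin-1-yl group nor the arrival of a six-membered aromatic ring accounts for it by itself. Compound 2 has only a limit of the assay, so the step from it gives a floor and not a full size: the limit of < 1000 nM in this assay, at which 1 of the 3 values shown sits.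

The compounds shown do not separate the nitrile of 4-cyanophenyl from the ring nitrogen of pyridin-2-yl, since the two groups differ in both features at once, and a plain phenyl ring at this carbon would be needed to tell these apart. They also leave open whether the result extends to pyridin-3-yl or pyridin-4-yl, or to a saturated amine such as morpholine.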